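Basic Side Chains on a Shared Core and Cell Growth

This account rests on a few compounds, and the source may have more. Where it says the series, first, only, none or still open, it means among the compounds named here.

Compound 1 `Cn1c(N)c(-c2nc3ccccc3[nH]2)c2nc(C#N)c(C#N)nc21`: > 50000 nM
Compound 2 `N#Cc1nc2c(-c3nc4ccccc4[nH]3)c(N)n(CCN3CCCC3)c2nc1C#N`: 6480 nM

In a functional assay on K562 cells (Homo sapiens) for antiproliferative activity, read by MTT assay, with a stated time of 48 h (on this read-out lower numbers stand for stronger inhibition and higher numbers for weaker inhibition), compound 1 gives only a limit, > 50000 nM, not a number. Compound 2 gives 6480 nM. Among the compounds with values here, the single measured step is an at least 7.7-fold lower number from compound 1 to compound 2 (0.88 log units; beyond the scatter), and its starting point is the limit (the limit of > 50000 nM in this assay, at which 1 of the 2 values shown sits). Compound 3 `CN(C)CCCn1c(N)c(-c2nc3ccccc3[nH]2)c2nc(C#N)c(C#N)nc21` carries 2-(dimethylamino)ethyl in place of hydrogen on a saturated chain carbon bound to an aromatic nitrogen. This change is of the same kind as the step of an at least 7.7-fold lower number from compound 1 to compound 2 (0.88 log units; beyond the scatter), so a drop of similar size is expected. Compound 3 is therefore estimated to give 7000 nM, with a range from 2500 nM to 25000 nM. That estimate corresponds to an at least 7.1-fold lower number from compound 1 to compound 3 (0.85 log units; beyond the scatter).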

Compound 3, half-maximal inhibitory concentration: 1730 nM
Compound 3: the middle estimate sits 4.0-fold (0.61 log units) above what was measured; measured number outside the range, below it.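

With 2-(dimethylamino)ethyl in place of hydrogen on a saturated chain carbon bound to an aromatic nitrogen, this assay shows an at least 28-fold lower number from compound 1 to compound 3 (1.46 log units; beyond the scatter), so a second amine-bearing chain also lowers the number. The exchange of pyrrolidin-1-yl for (dimethylamino)methyl gives a 3.7-fold lower number from compound 2 to compound 3 (0.57 log units; beyond the scatter), so at this position the two chains are not interchangeable. The first of these steps starts from a limit for compound 1: the limit of > 50000 nM in this assay, at which 1 of the 3 values shown sits.

On these data alone, it remains open how much of the gap between compound 2 and compound 3 belongs to the amine and how much to the chain length. Also open, as far as these compounds go, is how a morpholine, a piperidine, a longer chain or a carboxylic acid at the chain end would compare.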